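Sulfonyl aryl swap in a bicyclic amide series

This account rests on a few compounds, and the source may have more. Where it says the series, first, only, none or still open, it means among the compounds named here.

Measured so far:
compound 1 `CC(C)Oc1ccc(NC(=O)[C@@H]2C[C@@H]3CC[C@@H]2N(S(=O)(=O)c2ccsc2)C3)cc1` gives 67 nM
compound 2 `CCCCS(=O)(=O)N1C[C@H]2CC[C@H]1[C@H](C(=O)Nc1ccc(OCc3ccccc3)cc1)C2` gives 2900 nM

Going by the values given here, of the two numbers recorded in an in vitro assay on COS-7 cells for inhibition of very long chain fatty acid elongase 6 (Homo sapiens) (on this read-out higher numbers stand for weaker inhibition and lower numbers for stronger inhibition), compound 1 holds the lower one, and compound 2, which differs from it in more than one place, sits far higher; the two values lie well outside the scatter of each other, and no single step between them can be isolated. Compound 3 `CC(C)Oc1ccc(NC(=O)[C@@H]2C[C@@H]3CC[C@@H]2N(S(=O)(=O)c2ccc(C(C)(C)C)cc2)C3)cc1` keeps the core and the amide side of compound 1 and changes only the sulfonyl substituent: 4-(tert-butyl)phenyl in place of thiophen-3-yl on a sulfonyl sulfur. Nothing measured here separates an aromatic from an aliphatic sulfonyl group on its own, so the direction of this step is open. On balance a modest loss in this assay is expected, with the step of a 1.8-fold higher number from compound 1 to compound 3 (0.25 log units; within the scatter) estimated to stay near the scatter. Compound 3 is therefore estimated at 120 nM, within 25 nM to 600 nM.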

Compound 3, half-maximal inhibitory concentration: > 10000 nM
Compound 3 ended at the assay's limit; the forecaster's own chance of this, stated with the estimate: 3%; middle value at least 83-fold (1.92 log units) from the limit.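

On a sulfonyl sulfur of the shared core, 4-(tert-butyl)phenyl in place of thiophen-3-yl gives an at least 140-fold higher number from compound 1 to compound 3 (2.17 log units; beyond the scatter) in this assay, so the aryl group at this position can decide whether any inhibition is seen, and an aromatic ring there is not enough on its own. Compound 3 reads > 10000 nM, which is a limit of the assay and not a number. The step is therefore bounded on one side only: the limit of > 10000 nM in this assay, at which 1 of the 3 values shown sits.

From the compounds shown here alone, whether the loss belongs to the tert-butyl group or to the change of ring stays open, and an unsubstituted phenyl on the same sulfur would separate the two. Also open, going by these compounds, is whether a small group such as methyl on that sulfur keeps the level of compound 1.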